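Series notes: carbonyl-linked piperazine substituents on the shared core

This account rests on a few compounds, and the source may have more. Where it says the series, first, only, none or still open, it means among the compounds named here.

Measured so far:
compound 1, `COc1ccc(-c2cnc3nc(N)nc(N4CCN(Cc5ccccc5F)CC4)c3n2)cc1OC`, 700 nM
compound 2, `COc1ccc(-c2cnc3nc(N)nc(N4CCN(Cc5ccccc5)CC4)c3n2)cc1OC`, 900 nM
compound 3, `COc1ccc(-c2cnc3nc(N)nc(N4CCN(C(=O)NCc5ccc(F)cc5)CC4)c3n2)cc1OC`, 37 nM

All three share one core and differ only at the amine nitrogen in the ring. In a functional assay on cells (T-cell, Homo sapiens) for inhibition (a lower number here means a stronger inhibitor, a higher number a weaker inhibitor), compound 3 gives the lowest number of the three: its nearest neighbour is compound 1, and the step of a 19-fold lower number from compound 1 to compound 3 (1.28 log units; beyond the scatter) is large, as is a 24-fold lower number from compound 2 to compound 3 (1.39 log units; beyond the scatter). The step of a 1.3-fold higher number from compound 1 to compound 2 (0.11 log units; within the scatter) is within the scatter, so the hydrogen-for-fluoro exchange on the aromatic carbon alone tells little.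

Compound 4, `COc1ccc(-c2cnc3nc(N)nc(N4CCN(C(=O)COc5ccc(Cl)cc5)CC4)c3n2)cc1OC`, keeps the carbonyl on that nitrogen but changes what sits on it: (4-chlorophenoxy)methyl in place of (4-fluorobenzyl)amino on a carbonyl carbon. Among the compounds with values here, no measured pair isolates this exchange; the two large steps into compound 3 both bundle the arrival of the carbonyl with the (4-fluorobenzyl)carbamoyl as a whole, so the part that the carbonyl alone carries is unknown. Because compound 3 gives 37 nM and the carbonyl is retained, compound 4 is expected to stay nearer compound 3 than compound 1 or compound 2, with a modest weakening as the most likely outcome: the estimated step is a 3.2-fold higher number from compound 3 to compound 4 (0.51 log units; beyond the scatter). Compound 4 is therefore estimated at 120 nM, with a range from 30 nM to 500 nM.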

Compound 4, half-maximal inhibitory concentration: 0.5 nM
Beside the measured number, compound 4's estimate is 240-fold (2.38 log units) above it, outside the stated range (below it).
By their numbers in this assay, from the lowest: compound 4; then compound 3; then compounds 1 and 2 (each within the scatter of the next).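

In this assay the carbonyl on the ring nitrogen does not by itself set the number: with the carbonyl kept, the group on its carbon still gives a 74-fold lower number from compound 3 to compound 4 (1.87 log units; beyond the scatter) when (4-chlorophenoxy)methyl replaces (4-fluorobenzyl)amino. The whole substituent on the ring nitrogen spans a far wider range than compounds 1 to 3 showed, with a 1800-fold lower number from compound 2 to compound 4 (3.26 log units; beyond the scatter) and a 1400-fold lower number from compound 1 to compound 4 (3.15 log units; beyond the scatter) as the readings against the benzyl-type groups. The exchange removes a hydrogen-bond donor, adds a hydrogen-bond acceptor and swaps fluorine for chlorine in one step, and no measurement here gives a cause for the gain.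

Which of these parts carries the step stays open. A (4-fluorophenoxy)methyl group, or a plain carbon chain in place of the ether oxygen, would separate them.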